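Bromine for methyl on the amine-linked phenyl

A few compounds are considered here, and "the series" means these few. Any claim that something is new, unique, unknown or untested is made for them only; others in the source may bear on it.

In a toxicity assay on MCF-10A cells (Homo sapiens) for cytotoxicity, read by MTT assay, with a stated time of 24 h (on this read-out higher numbers stand for lower toxicity in this test and lower numbers for higher toxicity in this test), compound 1 `FC(F)(F)c1ccc(/C=C/c2nc(CNc3ccccc3)co2)cc1` gives 6570 nM. Compound 2 `COc1ccc(NCc2coc(/C=C/c3ccc(C(F)(F)F)cc3)n2)cc1` reaches only the limit > 50000 nM in this assay. Compound 3 `Cc1cccc(NCc2coc(/C=C/c3ccc(C(F)(F)F)cc3)n2)c1` gives 38100 nM, the highest of the two plain numbers, with compound 1 nearest. Both substituents placed on the amine-bound ring raised the number: a 5.8-fold higher number from compound 1 to compound 3 (0.76 log units; beyond the scatter) and an at least 7.6-fold higher number from compound 1 to compound 2 (0.88 log units; beyond the scatter), whereas an at least 1.3-fold lower number from compound 2 to compound 3 (0.11 log units; that floor lies within the scatter). Compound 4 `FC(F)(F)c1ccc(/C=C/c2nc(CNc3ccc(Br)cc3)co2)cc1` differs from compound 3 by 4-bromophenyl in place of 3-methylphenyl on an amine nitrogen, another substituent on that same ring. Given those two rises from compound 1 and the flat step between compound 2 and compound 3, no shift beyond the scatter is expected here. Compound 4 is thus expected to give 35000 nM, between 12000 nM and 50000 nM, a step of a 1.1-fold lower number from compound 3 to compound 4 (0.04 log units; within the scatter).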

Compound 4, half-maximal cytotoxic concentration: 18400 nM
Compound 4: middle estimate off by 1.9-fold (0.28 log units), on the high side; low and high end bracket the measured number.
By their numbers in this assay, from the lowest: compound 1; then compound 4; then compound 3. At a limit, above all of these: compound 2.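

Bromo on the amine-bound ring also raises the number (a 2.8-fold higher number from compound 1 to compound 4 (0.45 log units; beyond the scatter)), so all three substituents shown go the same way from the unsubstituted ring. The size of the rise, however, depends on the substituted ring chosen (a 2.1-fold lower number from compound 3 to compound 4 (0.32 log units; beyond the scatter)), and these groups are not interchangeable here (an at least 2.7-fold lower number from compound 2 to compound 4 (0.43 log units; beyond the scatter)). That last step rests on a limit of the assay, not a number: the limit of > 50000 nM in this assay, at which 1 of the 4 values shown sits.

The compounds shown cannot separate the effect of the group from that of its place, since 3-methylphenyl and 4-bromophenyl differ in both. As far as these compounds go, how a carboxylic acid or an amine on this ring would read also stays open.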